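Chlorophenyl to methoxyphenyl exchange: notes on compound 3

This account rests on a few compounds, and the source may have more. Where it says the series, first, only, none or still open, it means among the compounds named here.

Measured so far in a physicochemical assay for lipophilicity; on this read-out lower numbers stand for lower lipophilicity and higher numbers for higher lipophilicity:
- compound 1 `C[C@H]1CC[C@@H]2[C@@H](OC(=O)[C@]23CC(c2ccc(Cl)cc2)N(c2ccccc2)O3)[C@]2(C)C(=O)C=C[C@@]12O` gives 3.87
- compound 2 `C[C@H]1CC[C@@H]2[C@@H](OC(=O)[C@]23CC(c2ccccc2Cl)N(c2ccccc2)O3)[C@]2(C)C(=O)C=C[C@@]12O` gives 3.87

Compound 2 , at 3.87, stands level with compound 1. The next member, compound 3 `COc1cccc(C2C[C@@]3(ON2c2ccccc2)C(=O)O[C@@H]2[C@H]3CC[C@H](C)[C@]3(O)C=CC(=O)[C@@]23C)c1`, is still unmeasured and carries 3-methoxyphenyl in place of 2-chlorophenyl on a saturated ring carbon. For the measured compounds named here, only one measured step bears on this exchange, no change at the digits printed from compound 1 to compound 2 (within the scatter), and it only swaps one chlorophenyl group for another. Going by the values given here, no measured compound carries a methoxyphenyl group, so the size of this exchange has not been observed. On the structural change alone, a modest downward step in this assay is expected, with wide margins. The expected step is a number 0.42 log units lower from compound 2 to compound 3 (beyond the scatter), an estimate and not a measurement. For compound 3 the estimated value is 3.45, with an expected range from 3.05 to 3.85.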

Compound 3, partition coefficient: 3.25
The estimate for compound 3 lay 0.20 log units above the measured number, and the stated range covers the measured number.
By their numbers in this assay, from the lowest: compound 3; then compounds 1 and 2 (each within the scatter of the next).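

In this assay, the aryl group on this saturated ring carbon does register a change: 3-methoxyphenyl in place of 2-chlorophenyl gives a number 0.62 log units lower from compound 2 to compound 3 (beyond the scatter), and 3-methoxyphenyl in place of 4-chlorophenyl gives a number 0.62 log units lower from compound 1 to compound 3 (beyond the scatter). For the compounds shown here, the earlier exchange between the two chlorophenyl groups left the read-out level at the digits printed, so this is the first step that lies beyond the scatter. No available evidence accounts for the size of this step.

Compound 3 differs from both chlorophenyl compounds in the substituent and in its place on the phenyl ring, so the shown compounds cannot separate these two changes. Going by these compounds, how an amine or a carboxylic acid on that phenyl ring would read out in this assay remains open.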